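Pyrrolidinyl for furanyl: cytotoxicity outlook for compound 4

The compounds below may be only part of what the source reports. "The series", "measured", "known", "first", "only" and "open" are said of these compounds alone.

compound 1 `C=Cc1ccc(-c2cc(C)c3ncc(CSCCc4ccccc4)n3c2)cc1`: 20 ug/mL in an ADME assay on HEL cells (Homo sapiens) for cytotoxicity, with a stated time of 3 days; on this read-out higher numbers stand for lower toxicity in this test and lower numbers for higher toxicity in this test
compound 2 `Cc1cc(-c2ccc3[nH]ccc3c2)cn2c(CSCCc3ccccc3)cnc12`: >= 20 ug/mL, a limit of this assay
compound 3 `Cc1cc(-c2ccco2)cn2c(CSCCc3ccccc3)cnc12`: > 4 ug/mL, a limit of this assay

Compound 3 stands only at a limit in this assay, as the limit of > 4 ug/mL in this assay, at which 1 of the 3 values shown sits, shows. Its steps from the other two, a step that the limit leaves unreadable from compound 1 to compound 3 and a step that the two limits leave unreadable from compound 2 to compound 3, are unreadable; a number no lower from compound 1 to compound 2 (the limit leaves the size open) is likewise left open by the limit of >= 20 ug/mL in this assay, at which 1 of the 3 values shown sits. Compound 4 `Cc1cc(N2CCCC2)cn2c(CSCCc3ccccc3)cnc12` differs from compound 3 by pyrrolidin-1-yl in place of furan-2-yl on an aromatic carbon. No readable step therefore bears on this change; only the value of compound 1 and the limit of compound 2 give a footing. Compound 4 is expected to sit near them, estimated at 20 ug/mL within 4 ug/mL to 100 ug/mL, meaning an expected step that the limit leaves unreadable from compound 3 to compound 4, with a limit rather than a number quite possible.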

Compound 4, minimum cytotoxic concentration: 20 ug/mL
The estimate for compound 4 equals the measured number at the digits printed, within the range that was stated.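

In this assay, the non-aromatic pyrrolidin-1-yl on this aromatic carbon gives a second firm number for the series, with no change at the digits printed from compound 1 to compound 4 (within the scatter), so this read-out does not depend on an aromatic ring at this position in this pair. Against the indolyl compound, the result is a number no higher from compound 2 to compound 4 (the limit leaves the size open). The step from compound 3 to compound 4 cannot be read, and the value of compound 3 is a limit: the limit of > 4 ug/mL in this assay, at which 1 of the 4 values shown sits.

Open remains how a morpholine ring or an open-chain dimethylamino group at this position would read in this assay.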